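Chlorophenyl for difluorophenyl on the ring nitrogen

The compounds below may be only part of what the source reports. "The series", "measured", "known", "first", "only" and "open" are said of these compounds alone.

Compound 1 `COc1cc(/C=C/C(C)=O)ccc1OCc1cn(-c2c(F)cccc2F)nn1`: in a functional assay on PC-3 cells (Homo sapiens) for antiproliferative activity, read by MTT assay, with a stated time of 48 h (a lower number here means a stronger inhibitor, a higher number a weaker inhibitor), compound 1 gives 24200 nM.
Compound 2 `COc1cc(/C=C/C(C)=O)ccc1OCc1cn(-c2ccc(C(F)(F)F)c(C(F)(F)F)c2)nn1`: in this assay compound 2 gives 67200 nM.

For the measured compounds named here, of the two numbers so far, compound 1 has the lower one; the gap to compound 2 is beyond the usual scatter, so compound 1 is the more active of the pair. Compound 3 `COc1cc(/C=C/C(C)=O)ccc1OCc1cn(-c2ccccc2Cl)nn1` keeps the shared core of compound 1 and differs only in the group on the ring nitrogen: 2-chlorophenyl in place of 2,6-difluorophenyl on an aromatic nitrogen. Going by the values given here, no measured pair shows a change of this kind, so the size of the step has to be guessed. Since both measured values sit in the same broad region and the swap is one small aryl group for another, the step from compound 1 to compound 3 is expected to be none beyond the scatter, in no particular direction: a 1.0-fold higher number from compound 1 to compound 3 (0.01 log units; within the scatter). Compound 3 is therefore estimated at 25000 nM in this assay, with a range from 10000 nM to 60000 nM.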

Compound 3, half-maximal inhibitory concentration: 48000 nM
Estimate against measurement, compound 3: 1.9-fold (0.28 log units) below; low and high end bracket the measured number.
By their numbers in this assay, from the lowest: compounds 1, 3 and 2 (each within the scatter of the next, the first and the last beyond it).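

In this assay, placing 2-chlorophenyl in the position of 2,6-difluorophenyl on the aromatic nitrogen gives a 2.0-fold higher number from compound 1 to compound 3 (0.30 log units; within the scatter) and so gives the series its first single-group step at this position. A move from two fluorine atoms to one chlorine atom on the phenyl ring is therefore not resolved from the scatter here. Compound 3 also lies within the scatter of both compound 1 and compound 2, although those two lie beyond it of each other, so the three aryl groups do not separate into distinct levels. Nothing available explains these numbers.

Still open, from the compounds shown here alone, is whether plain phenyl or 2-fluorophenyl on this nitrogen would fall in the same range. An amine or a carboxylic acid on the phenyl ring could also give a step beyond the scatter from compound 1.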